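The compounds below may be only part of what the source reports. "The series", "measured", "known", "first", "only" and "open" are said of these compounds alone.

Values in a functional assay on K562 cells (Homo sapiens) for cytotoxicity, read by MTT assay, with a stated time of 48 h; a higher number here means a weaker inhibitor, a lower number a stronger inhibitor:

compound 1 `CCNc1n[n+]([O-])c2ccccc2[n+]1[O-]`: 4500 nM
compound 2 `[O-][n+]1nc(NC2CCCCC2)[n+]([O-])c2ccccc21`: 2600 nM
compound 3 `CCCCCCCCNc1n[n+]([O-])c2ccccc2[n+]1[O-]`: 4700 nM

All three values lie within the scatter of one another, so compound 3 stands apart from neither compound 1 nor compound 2 in this assay. Compound 4 `C=CCNc1n[n+]([O-])c2ccccc2[n+]1[O-]` has not yet been measured. It differs from compound 3 as follows: vinyl in place of heptyl on a saturated chain carbon bound to a nitrogen on an aromatic ring. In words, this is vinyl in place of heptyl on a saturated chain carbon bound to a nitrogen on an aromatic ring.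

Going by the values given here, two measured steps bear on this change. Hexyl in place of hydrogen on the chain gave a 1.0-fold higher number from compound 1 to compound 3 (0.02 log units; within the scatter), and cyclohexyl in place of ethyl gave a 1.7-fold lower number from compound 1 to compound 2 (0.24 log units; within the scatter). Among the compounds with values here, neither step leaves the scatter, although no measured compound yet carries a double bond in its chain. No step beyond the scatter is therefore expected in this assay. The step expected is a 1.2-fold lower number from compound 3 to compound 4 (0.07 log units; within the scatter). Compound 4 is estimated at 4000 nM, with an expected range of 2000 nM to 8000 nM.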

Compound 4, half-maximal inhibitory concentration: 11200 nM
The estimate for compound 4 lay 2.8-fold (0.45 log units) below the measured number, outside the stated range (above it).
By their numbers in this assay, from the lowest: compounds 2, 1 and 3 (each within the scatter of the next); then compound 4.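

In this assay, going by these compounds alone, the group on this nitrogen proves able to shift the number: the earlier compounds all stayed within the scatter of one another, whereas the change that brings in a double bond gives a 2.4-fold higher number from compound 3 to compound 4 (0.38 log units; beyond the scatter) in this series. The shift runs the same way against the other two compounds, with a 2.5-fold higher number from compound 1 to compound 4 (0.40 log units; beyond the scatter) and a 4.3-fold higher number from compound 2 to compound 4 (0.63 log units; beyond the scatter), which leaves compound 4 as the weakest of the four in this assay. No evidence at hand accounts for this shift.

Compound 4 shortens the chain and brings in a double bond in a single change, and the compounds shown do not separate the two. Going by these compounds, whether a saturated propyl chain on the same nitrogen would stay within the scatter of compound 1 remains open.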